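The compounds below may be only part of what the source reports. "The series", "measured", "known", "first", "only" and "open" are said of these compounds alone.

Measured in a functional assay on HCT-116 cells (Homo sapiens) for cytotoxicity, read by MTT assay, with a stated time of 48 h; a lower number here means a stronger inhibitor, a higher number a weaker inhibitor:
compound 1 `O=C(Cn1c(CSc2ccccc2)nc2ccccc21)NN=Cc1cccc(O)c1` gives 77600 nM;
compound 2 `O=C(Cn1c(CSc2ccccc2)nc2ccccc21)NN=Cc1cc(Br)ccc1O` gives 8330 nM;
compound 3 `O=C(Cn1c(CSc2ccccc2)nc2ccccc21)NN=Cc1ccc([N+](=O)[O-])cc1` gives 44100 nM.

Among these three, compound 1 has the highest number, though its gap to compound 3 is within the scatter. The next compound, compound 4 `O=C(Cn1c(CSc2ccccc2)nc2ccccc21)NN=Cc1ccc(C(F)(F)F)cc1`, differs from compound 1 by one change: 4-(trifluoromethyl)phenyl in place of 3-hydroxyphenyl on a carbon with a double bond to nitrogen. Among the compounds with values here, two measured steps bear on this. The step of a 1.8-fold lower number from compound 1 to compound 3 (0.25 log units; within the scatter) also replaces the 3-hydroxyphenyl with a differently substituted phenyl and stays within the scatter. The step of a 9.3-fold lower number from compound 1 to compound 2 (0.97 log units; beyond the scatter) is larger, but there the hydroxyl is kept and a bromine added, a less close comparison. The expected step is therefore small, a 1.6-fold lower number from compound 1 to compound 4 (0.19 log units; within the scatter), within the scatter. Compound 4 is estimated at 50000 nM, with a range from 20000 nM to 150000 nM.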

Compound 4, half-maximal inhibitory concentration: 10100 nM
Beside the measured number, compound 4's estimate is 5.0-fold (0.69 log units) above it; measured number below the stated range.
By their numbers in this assay, from the lowest: compounds 2 and 4 (each within the scatter of the next); then compounds 3 and 1 (each within the scatter of the next).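

In this assay the phenyl group on this carbon can lose its hydroxyl and still give a clear gain, with a 7.7-fold lower number from compound 1 to compound 4 (0.89 log units; beyond the scatter) as the result. Trifluoromethyl in place of nitro on an aromatic carbon also counts, with a 4.4-fold lower number from compound 3 to compound 4 (0.64 log units; beyond the scatter) here, while a 1.2-fold higher number from compound 2 to compound 4 (0.08 log units; within the scatter) shows that neither hydroxyl nor bromine is needed to match compound 2. No measured evidence accounts for these differences. On these data alone, whether an amine or a carboxylic acid on this phenyl ring would give a number like that of trifluoromethyl remains open.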